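Chain-carbon substituent change in the trifluoromethoxy-aniline amide series

The source may report more compounds than this note shows. Statements on the series, on what has been measured and on what is new or still open speak of the compounds shown alone.

Among the measured compounds shown here, compound 2 `C[C@@H](CNc1ccc(OC(F)(F)F)cc1)NC(=O)[C@@H](CC(=O)N1CCOCC1)CC1CCCC1` stands lowest of the two numbers so far in an assay on isolated protein for inhibition of cathepsin S (Homo sapiens) (a higher number here means a weaker inhibitor, a lower number a stronger inhibitor), where compound 2 gives 31 nM. Its nearest neighbour is compound 1 `C[C@@H](CNc1ccc(OC(F)(F)F)cc1)NC(=O)[C@@H](CC(=O)N1CCOCC1)CC(C)(C)C`, which in this assay gives 408 nM; the step of a 13-fold lower number from compound 1 to compound 2 (1.12 log units; beyond the scatter) is large and lies at the saturated chain carbon two bonds from the carbonyl carbon. Compound 3 `CC(C)[C@@H](CNc1ccc(OC(F)(F)F)cc1)NC(=O)[C@@H](CC(=O)N1CCOCC1)CC1CCCC1` differs from compound 2 at another place: isopropyl in place of methyl on a saturated chain carbon bound to an amide-type nitrogen and a saturated chain carbon. For the measured compounds named here, no measured step touches this carbon, so the one step available says nothing direct about the change. The shared core is otherwise unchanged, and with no comparison at this position, no step beyond the scatter is expected in this assay in either direction. For compound 3 in this assay the number is therefore estimated at 28 nM, within a range of 8 nM to 100 nM. This means an expected step from compound 2 to compound 3 of a 1.1-fold lower number from compound 2 to compound 3 (0.04 log units; within the scatter), with the range left wide to cover both directions.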

Compound 3, inhibition constant: 38 nM
The estimate for compound 3 lay 1.4-fold (0.13 log units) below the measured number; the range from low to high includes it.
By their numbers in this assay, from the lowest: compounds 2 and 3 (each within the scatter of the next); then compound 1.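

At the saturated chain carbon bound to an amide-type nitrogen and a saturated chain carbon, isopropyl in place of methyl gives a 1.2-fold higher number from compound 2 to compound 3 (0.09 log units; within the scatter) in this assay, so this carbon accepts isopropyl, with 3 heavy atoms against 1 for methyl, without a step beyond the scatter. This contrasts with the large change at the saturated chain carbon two bonds along the chain from a carbonyl carbon, a 13-fold lower number from compound 1 to compound 2 (1.12 log units; beyond the scatter), although the comparison at the new carbon rests on a single pair with cyclopentyl held constant. No measured evidence here accounts for either result.

Open, going by these compounds, is whether a longer chain, a primary amine or a carboxylic acid on this carbon would also stay within the scatter of compound 2. Also open, on these data alone, is whether isopropyl in place of methyl gives the same result with tert-butyl in place of cyclopentyl.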